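The source may report more compounds than this note shows. Statements on the series, on what has been measured and on what is new or still open speak of the compounds shown alone.

Measured in a functional assay on MCF7 cells (Homo sapiens) for antiproliferative activity, read by MTT assay, with a stated time of 48 h; a lower number here means a stronger inhibitor, a higher number a weaker inhibitor:
compound 1 `N#CC1=C(N)Oc2c(c3nc4ccccc4nc3c3ccccc23)C12C(=O)N(Cc1cnnn1-c1ccc(F)cc1)c1ccccc12`, a limit only, > 50000 nM;
compound 2 `COc1ccc(-n2nncc2CN2C(=O)C3(C(C#N)=C(N)Oc4c3c3nc5ccccc5nc3c3ccccc43)c3ccccc32)cc1`, a limit only, > 50000 nM.

Compound 1 stands at the limit of this assay and has no number of its own. Compound 2 sits at the same limit. Going by the values given here, the one measured step, a step that the two limits leave unreadable from compound 1 to compound 2, cannot be read for size, since the limit of > 50000 nM in this assay, at which 2 of the 2 values shown sit, covers both of the values shown. The step to compound 3 `Cc1ccc(-n2nncc2CN2C(=O)C3(C(C#N)=C(N)Oc4c3c3nc5ccccc5nc3c3ccccc43)c3ccccc32)cc1Cl` changes (3-chloro-4-methylphenyl in place of 4-fluorophenyl on an aromatic nitrogen). Among the compounds with values here, no measured step touches the group that enters, and the only comparison, methoxy in place of fluoro on an aromatic carbon, left the compound at the limit. Compound 3 is therefore expected to remain at the limit of this assay as well. The estimate for compound 3 in this assay is 70000 nM, between 20000 nM and 250000 nM. The expected step is a step that the limit leaves unreadable from compound 1 to compound 3, none beyond the scatter.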

Compound 3, half-maximal inhibitory concentration: > 50000 nM
Compound 3 gave a limit, no number; the forecaster's own chance of this, stated with the estimate: 80%; the middle value is on the limit's open side.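

No new step can be read in this assay among compound 1, compound 2 and compound 3, as each gives only a limit: the limit of > 50000 nM in this assay, at which 3 of the 3 values shown sit.

Whether 4-fluorophenyl, 4-methoxyphenyl or 3-chloro-4-methylphenyl on the aromatic nitrogen makes any difference to activity stays open, as does any order among these compounds.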